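This account rests on a few compounds, and the source may have more. Where it says the series, first, only, none or still open, it means among the compounds named here.

Measured in a functional assay on CEM-DNR-bulk cells (Homo sapiens), read by MTT assay, with a stated time of 72 h; a higher number here means a weaker inhibitor, a lower number a stronger inhibitor:
compound 1 `COc1ncnc2c1c(-c1ccsc1)cn2[C@@H]1O[C@H](CO)[C@@H](O)[C@H]1O` gives 7640 nM;
compound 2 `COc1ncnc2c1c(-c1cccs1)cn2[C@@H]1O[C@H](CO)[C@@H](O)[C@H]1O` gives 12100 nM;
compound 3 `CNc1ncnc2c1c(-c1cccs1)cn2[C@@H]1O[C@H](CO)[C@@H](O)[C@H]1O` gives > 20000 nM, which is a limit of the assay and not a number.

Compound 3 sits at the limit of > 20000 nM in this assay, at which 1 of the 3 values shown sits. From compound 2 to compound 1 the change is thiophen-3-yl in place of thiophen-2-yl on an aromatic carbon, and it brought a 1.6-fold lower number from compound 2 to compound 1 (0.20 log units; within the scatter). From compound 2 to compound 3 the two cores differ by methylamino in place of methoxy on an aromatic carbon, with an at least 1.6-fold higher number from compound 2 to compound 3 (0.21 log units; that floor lies within the scatter).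

Compound 4 `CNc1ncnc2c1c(-c1ccsc1)cn2[C@@H]1O[C@H](CO)[C@@H](O)[C@H]1O` has not been measured in this assay. It differs from compound 3 by thiophen-3-yl in place of thiophen-2-yl on an aromatic carbon, the same change as that made from compound 2 to compound 1, at the same place. Compound 3 itself stands only at a limit, and its exact number is not known. Resting on a 1.6-fold lower number from compound 2 to compound 1 (0.20 log units; within the scatter), the expected step is an at least 1.1-fold lower number from compound 3 to compound 4 (0.04 log units; that floor lies within the scatter), a small one within the scatter. Compound 4 is therefore expected to give about 18000 nM in this assay, with the estimate spanning 8000 nM to 45000 nM, and there is a fair chance that only a limit is reported for it.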

Compound 4, half-maximal inhibitory concentration: > 20000 nM
Compound 4: only a limit was reported; the forecaster's own chance of this, stated with the estimate: 50%; at least 1.1-fold (0.04 log units) between middle value and limit.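

In this assay compound 4 gives > 20000 nM, which is a limit of the assay and not a number, and the step between compound 3 and compound 4 cannot be read. Methylamino in place of methoxy on an aromatic carbon, carried to the core that bears thiophen-3-yl, gives an at least 2.6-fold higher number from compound 1 to compound 4 (0.41 log units; beyond the scatter), so on this core the change is seen beyond the scatter, and its direction agrees with the floor on the core that bears thiophen-2-yl. This shows that the change can be carried to the second core without any sign of reversal, but it does not show that its size is the same on both cores, since only floors are known: the same change on two cores in this assay, an at least 1.6-fold higher number (0.21 log units; that floor lies within the scatter) from compound 2 to compound 3 and an at least 2.6-fold higher number (0.41 log units; beyond the scatter) from compound 1 to compound 4; the limit leaves it open whether they differ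

From the compounds shown here alone, how far compound 3 and compound 4 lie past the limit stays open, and this bounds all that can be read from them: the limit of > 20000 nM in this assay, at which 2 of the 4 values shown sit. Also open is whether an unsubstituted amino group or a longer ethoxy chain in the place of methoxy would bring numbers that can be read on either core.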